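Amide series: substituents on the aminopyridyl nitrogen

A few compounds are considered here, and "the series" means these few. Any claim that something is new, unique, unknown or untested is made for them only; others in the source may bear on it.

Compound 2 `CC(C)(C)c1ccc(NC(=O)c2ccc(-c3ncccc3NC3CCCC3)cc2)cc1` gives the highest number of the two measured in a functional assay for antagonist activity at transient receptor potential cation channel subfamily V member 1 (Rattus norvegicus) (on this read-out lower numbers stand for stronger inhibition and higher numbers for weaker inhibition), at 44 nM; compound 1 `CC(C)(C)c1ccc(NC(=O)c2ccc(-c3ccccn3)cc2)cc1` gives 8 nM. Among the compounds with values here, the only step measured, a 5.5-fold higher number from compound 1 to compound 2 (0.74 log units; beyond the scatter), concerns the arrival of the cyclopentylamino group, not its exchange. Compound 3 `CCS(=O)(=O)Nc1cccnc1-c1ccc(C(=O)Nc2ccc(C(C)(C)C)cc2)cc1` carries ethylsulfonyl in place of cyclopentyl on a nitrogen on an aromatic ring. Within the data shown here, no measured step bears directly on this exchange, so the expectation rests on the scale of a 5.5-fold higher number from compound 1 to compound 2 (0.74 log units; beyond the scatter) alone. For compound 3 a step of a 1.5-fold lower number from compound 2 to compound 3 (0.17 log units; within the scatter) is expected, with wide uncertainty, giving an estimated 30 nM in this assay, ranging from 8 nM to 120 nM.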

Compound 3, half-maximal inhibitory concentration: 4 nM
Compound 3: the middle estimate sits 7.5-fold (0.88 log units) above what was measured, and the stated range ends above it.
By their numbers in this assay, from the lowest: compounds 3 and 1 (each within the scatter of the next); then compound 2.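

The group on this nitrogen on an aromatic ring decides the read-out, not merely the presence of a substituent: ethylsulfonyl in place of cyclopentyl gives an 11-fold lower number from compound 2 to compound 3 (1.04 log units; beyond the scatter) in this assay. Against the core without a substituent, (ethylsulfonyl)amino gives a 2.0-fold lower number from compound 1 to compound 3 (0.30 log units; within the scatter), whereas cyclopentylamino gave a 5.5-fold higher number from compound 1 to compound 2 (0.74 log units; beyond the scatter). No data on hand account for this difference.

Open, from the compounds shown here alone, is whether an acetyl group or the longer propylsulfonyl chain on this nitrogen would stay level with compound 3. Going by these compounds, whether the ethyl part of the sulfonyl group matters also remains open.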